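This account rests on a few compounds, and the source may have more. Where it says the series, first, only, none or still open, it means among the compounds named here.

Measured so far in a functional assay on HCT-116 cells (Homo sapiens) for cytotoxicity, read by MTT assay, with a stated time of 72 h; a higher number here means a weaker inhibitor, a lower number a stronger inhibitor

- compound 1 `Nc1ccccc1NC(=O)c1ccc(CNC(=O)c2cc3cccnc3[nH]2)cc1` gives 10000 nM
- compound 2 `Nc1ccccc1NC(=O)c1ccc(NC(=S)NCc2ccc(Cl)nc2)cc1` gives 6100 nM
- compound 3 `Nc1ccccc1NC(=O)c1ccc(NC(=S)NCc2ccccc2F)cc1` gives 6300 nM

Compound 1 stands level with compound 2 and compound 3, and the gaps among the three numbers all stay within the usual scatter. Compound 4 `Nc1ccccc1NC(=O)c1ccc(CNC(=O)c2cc3cnccc3[nH]2)cc1` keeps the core of compound 1 and differs only on a carbonyl carbon, where the change is a group of 9 heavy atoms (7 carbon, 2 nitrogen; one five-membered aromatic ring with 1 hetero atom, one six-membered aromatic ring with 1 hetero atom) in place of a group of 9 heavy atoms (7 carbon, 2 nitrogen; one five-membered aromatic ring with 1 hetero atom, one six-membered aromatic ring with 1 hetero atom), on a carbonyl carbon and the same atoms are joined differently. Among the compounds with values here, the only measured step, a 1.0-fold higher number from compound 2 to compound 3 (0.01 log units; within the scatter), lies within the scatter and concerns a different group, which makes it weak guidance. No step beyond the scatter is therefore expected in this assay. The estimated change is a 1.4-fold lower number from compound 1 to compound 4 (0.15 log units; within the scatter) and is expected to stay within the scatter. For compound 4 the expected value is 7000 nM, with an estimated range from 2500 nM to 15000 nM.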

Compound 4, half-maximal inhibitory concentration: 4000 nM
Compound 4: the middle estimate sits 1.8-fold (0.24 log units) above what was measured; the measured number falls inside the stated range.
By their numbers in this assay, from the lowest: compounds 4, 2, 3 and 1 (each within the scatter of the next, the first and the last beyond it).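

In this assay, within the data shown here, joining the same atoms differently in the group on the carbonyl carbon gives a 2.5-fold lower number from compound 1 to compound 4 (0.40 log units; beyond the scatter), the first step here beyond the scatter. This place therefore responds to how the group is joined, even with its counts of atoms, hydrogen-bond donors and acceptors unchanged. Nothing available accounts for the shift. Still open, from the compounds shown here alone, is how a different group on this carbonyl carbon, such as a plain phenyl ring or a morpholine, would compare with compound 4.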